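Amide amine variation at the carbonyl of the sulfonylpiperazine series

This account rests on a few compounds, and the source may have more. Where it says the series, first, only, none or still open, it means among the compounds named here.

Compound 3 `CC1CCN(C(=O)C(C)N2CCN(S(=O)(=O)c3ccc(C(C)(C)C)cc3)CC2)CC1` carries 4-methylpiperidin-1-yl on the carbonyl carbon. In an ADME assay on HepG2 cells (Homo sapiens) for inhibition, with a stated time of 48 h (on this read-out higher numbers stand for an effect only at larger amounts of compound and lower numbers for an effect already at smaller amounts), compound 3 returns only a limit, > 40000 nM. Compound 1 `CCN(CC)C(=O)C(C)N1CCN(S(=O)(=O)c2ccc(C(C)(C)C)cc2)CC1`, with diethylamino in the same place, gives a limit as well; in this assay compound 1 sits at > 40000 nM. Compound 2 `CC(C(=O)N1CCC(F)(F)CC1)N1CCN(S(=O)(=O)c2ccc(C(C)(C)C)cc2)CC1`, with 4,4-difluoropiperidin-1-yl there, also reaches no number, compound 2 showing > 40000 nM. Because (the limit of > 40000 nM in this assay, at which 3 of the 3 values shown sit), the steps a step that the two limits leave unreadable from compound 1 to compound 2, a step that the two limits leave unreadable from compound 1 to compound 3 and a step that the two limits leave unreadable from compound 2 to compound 3 cannot be sized, and compound 3 stands at the same limit as the other two, with no order among them.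

Compound 4 `CC(C(=O)N1CCN(C)CC1)N1CCN(S(=O)(=O)c2ccc(C(C)(C)C)cc2)CC1` differs from compound 3 in a single place: 4-methylpiperazin-1-yl in place of 4-methylpiperidin-1-yl on a carbonyl carbon. The three measured steps all concern the same amide nitrogen substituent, and each of them was left unreadable by the limit, so no direction can be taken from them. The expectation for compound 4 is therefore another limit, with the step that the limit leaves unreadable from compound 3 to compound 4 expected to stay within the scatter. Compound 4 is estimated at 60000 nM in this assay, with a range from 20000 nM to 200000 nM.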

Compound 4, half-maximal effective concentration: > 40000 nM
Compound 4: a limit, no number (the forecaster's own chance of this, stated with the estimate: 85%); the middle value is on the limit's open side.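

Among these compounds, no step from compound 1, compound 2 or compound 3 to compound 4 can be read, because all four compounds give a limit rather than a number: the limit of > 40000 nM in this assay, at which 4 of the 4 values shown sit.

The compounds shown leave open whether any amine on the carbonyl carbon gives a measurable half-maximal effective concentration in this assay and how these four compounds compare.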